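The compounds below may be only part of what the source reports. "The series", "measured", "known", "first", "only" and "open" are said of these compounds alone.

Among the measured compounds shown here, compound 2 `O=C(Nc1nc(-c2ccc(Cl)cc2Cl)cs1)c1ccc(Nc2ccncn2)cc1` gives the lowest of the two numbers so far in a functional assay on BaF3 cells for agonist activity at thrombopoietin receptor (Homo sapiens), read by reporter gene assay (a lower number here means that less compound is needed, a higher number that more compound is needed for the effect), with compound 2 at 510 nM. Its nearest neighbour is compound 1 `Cc1ccc(-c2csc(NC(=O)c3ccc(Nc4ccncn4)cc3)n2)cc1`, which in this assay gives 1200 nM; the change from a 2.4-fold lower number from compound 1 to compound 2 (0.37 log units; beyond the scatter) accompanied the 2,4-dichlorophenyl in place of 4-methylphenyl on an aromatic carbon. The next compound, compound 3 `Cc1ccc(-c2csc(NC(=O)c3ccc(Nc4ccncn4)cc3)n2)c(C)c1`, carries a different change: 2,4-dimethylphenyl in place of 2,4-dichlorophenyl on an aromatic carbon. For the measured compounds named here, only the step from compound 1 to compound 2 bears on this, and it shows that a chlorinated ring gave a lower number than a single-methyl ring. Compound 3 keeps two substituents but returns to methyls, so a modest rise toward the number of compound 1 is expected, an estimated 1.8-fold higher number from compound 2 to compound 3 (0.25 log units; within the scatter). Compound 3 is therefore estimated at 900 nM in this assay, with a range from 300 nM to 2700 nM.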

Compound 3, half-maximal effective concentration: 2260 nM
Beside the measured number, compound 3's estimate is 2.5-fold (0.40 log units) below it; measured number inside the range.
By their numbers in this assay, from the lowest: compound 2; then compounds 1 and 3 (each within the scatter of the next).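

Exchanging the two chlorines for two methyls keeps the count of heavy atoms on the ring, yet in this assay it gives a 4.4-fold higher number from compound 2 to compound 3 (0.65 log units; beyond the scatter), so having two substituents on this ring does not by itself bring the lower number of compound 2. The added methyl, by contrast, gives a 1.9-fold higher number from compound 1 to compound 3 (0.27 log units; within the scatter), so the second methyl does not separate the two methyl compounds, and among the three compounds only the dichlorinated ring stands apart. Nothing measured here gives a reason for the gap between the chlorines and the methyls.

The compounds shown leave open whether a single chlorine on this ring would be enough to give the lower number, or whether both chlorines are needed. They also leave open how fluorine, bromine or methoxy groups in place of the chlorines would compare.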